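A few compounds are considered here, and "the series" means these few. Any claim that something is new, unique, unknown or untested is made for them only; others in the source may bear on it.

In a functional assay on the whole organism with Mus musculus as the target, in the rotarod test (on this read-out lower numbers stand for an effect already at smaller amounts and higher numbers for an effect only at larger amounts of compound), compound 1 `CN(C(=O)CNC(=O)CN1CCCCC1)c1ccc(Cl)cc1C(=O)c1ccccc1Cl` gives > 100 mg/kg, which is a limit of the assay and not a number. Compound 1 therefore stands at the limit of > 100 mg/kg in this assay, at which 1 of the 2 values shown sits. Going by the values given here, the only numerical reading so far comes from compound 2 `NCC(=O)NCC(=O)Nc1ccc([N+](=O)[O-])cc1C(=O)c1ccccc1`, which gives 24.8 mg/kg in this assay. Among the compounds with values here, no step between measured compounds is available, so the data offer no direct precedent for the next change.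

Compound 3 `CN(C(=O)CNC(=O)c1ccccc1)c1ccc(Cl)cc1C(=O)c1ccccc1Cl` keeps the core of compound 1 but carries phenyl in place of (piperidin-1-yl)methyl on a carbonyl carbon, turning (((piperidin-1-yl)methyl)carbonyl)amino into benzamido: phenyl in place of (piperidin-1-yl)methyl on a carbonyl carbon. Within the data shown here, with no measured step to guide the expectation and only a limit as the starting point, the direction of any shift remains open. The expected step that the limit leaves unreadable from compound 1 to compound 3 is no larger than the usual scatter, and a further limit rather than a number would be no surprise. For compound 3 the estimated value is 120 mg/kg, with an expected range from 40 mg/kg to 300 mg/kg.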

Compound 3, dose for half-maximal effect: > 100 mg/kg
Compound 3 gave a limit, no number; the forecaster's own chance of this, stated with the estimate: 60%; the middle value does not contradict the limit.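

Going by these compounds alone, compound 1 and compound 3 each end at a limit of the assay and not at a number, so no step between them can be read in this assay, where the picture is this: the limit of > 100 mg/kg in this assay, at which 2 of the 3 values shown sit. The compounds shown leave open whether phenyl in place of (piperidin-1-yl)methyl on a carbonyl carbon shifts the dose at all.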